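This account rests on a few compounds, and the source may have more. Where it says the series, first, only, none or still open, it means among the compounds named here.

Compound 2 `C/C(=N\OCC(=O)Nc1cccc(F)c1)C1=C(O)c2ccccc2S(=O)(=O)N1C` shares its core with compound 1 `CCOC1=C(/C(C)=N/OCC(=O)Nc2cccc(F)c2)N(C)S(=O)(=O)c2ccccc21` and differs from it only by hydrogen in place of ethyl on an oxygen on an unsaturated carbon. In a functional assay on THP-1 cells (Homo sapiens) for inhibition, read by ELISA, with stated times of 2 h and 48 h (on this read-out lower numbers stand for stronger inhibition and higher numbers for weaker inhibition), compound 1 gives > 20000 nM, which is a limit of the assay and not a number. In this assay compound 2 gives > 20000 nM, again only a limit. The step that the two limits leave unreadable from compound 1 to compound 2 cannot be read, because both values sit at the limit of > 20000 nM in this assay, at which 2 of the 2 values shown sit. Compound 3 `C/C(=N\OCC(=O)Nc1ccc(F)c(Cl)c1)C1=C(O)c2ccccc2S(=O)(=O)N1C` differs from compound 2 by 3-chloro-4-fluorophenyl in place of 3-fluorophenyl on an amide-type nitrogen. For the measured compounds named here, no measured step bears on this change, and compound 2 itself stands only at a limit, so the values shown give no size and no direction for it. Compound 3 is therefore expected to stand at the limit as well, with an estimate of 30000 nM between 8000 nM and 100000 nM. The step from compound 2 to compound 3 is expected to be a step that the limit leaves unreadable from compound 2 to compound 3, which is not readable against a limit.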

Compound 3, half-maximal inhibitory concentration: > 20000 nM
Compound 3: no number, only a limit (the forecaster's own chance of this, stated with the estimate: 85%); the middle value is on the limit's open side.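

In this assay compound 3 gives > 20000 nM, which is a limit of the assay and not a number. For the compounds shown here, compound 2 also stands at a limit, so no step from it to compound 3 can be read: the limit of > 20000 nM in this assay, at which 3 of the 3 values shown sit. The compounds shown leave open which change to the shared core, if any, would give a measurable value in this assay.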